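This account rests on a few compounds, and the source may have more. Where it says the series, first, only, none or still open, it means among the compounds named here.

Measured in a functional assay on CCRF-CEM cells (Homo sapiens), read by MTT assay, with a stated time of 72 h; on this read-out lower numbers stand for stronger inhibition and higher numbers for weaker inhibition:

- Compound 1 `CSc1ncnc2c1c(-c1ccoc1)cn2[C@@H]1O[C@H](CO)[C@@H](O)[C@H]1O`: 14200 nM
- Compound 2 `CSc1ncnc2c1c(-c1ccsc1)cn2[C@@H]1O[C@H](CO)[C@@H](O)[C@H]1O`: > 20000 nM
- Compound 3 `CSc1ncnc2c1c(-c1ccccc1)cn2[C@@H]1O[C@H](CO)[C@@H](O)[C@H]1O`: > 20000 nM

Compound 2 has no exact number, and its > 20000 nM is a limit of the assay, not a measurement. Compound 2 therefore stands at the limit of > 20000 nM in this assay, at which 2 of the 3 values shown sit. Compound 3 gives the same kind of reading, and its > 20000 nM is also a limit.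

Compound 4 `CN(C)c1ncnc2c1c(-c1ccsc1)cn2[C@@H]1O[C@H](CO)[C@@H](O)[C@H]1O` keeps the thiophen-3-yl group of compound 2 and differs in one place: dimethylamino in place of methylsulfanyl on an aromatic carbon. Dimethylamino takes the place of methylsulfanyl on an aromatic carbon.

The measured steps bear on this only indirectly, since each swaps the other group and keeps methylsulfanyl. There is an at least 1.4-fold higher number from compound 1 to compound 2 (0.14 log units; that floor lies within the scatter) and an at least 1.4-fold higher number from compound 1 to compound 3 (0.14 log units; that floor lies within the scatter), and both floors lie within the scatter. There is also a step that the two limits leave unreadable from compound 2 to compound 3, which has no readable size. Going by the values given here, no measured pair shows the new change, so its size and direction remain open.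

The expectation therefore starts from compound 2 at > 20000 nM, and no step beyond the scatter is expected. The estimated step is an at least 1.1-fold lower number from compound 2 to compound 4 (0.04 log units; that floor lies within the scatter), and another reading at the limit would be no surprise. The expected value for compound 4 is 18000 nM, with an estimated range of 5000 nM to 40000 nM.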

Compound 4, half-maximal inhibitory concentration: 3480 nM
For compound 4 the middle estimate is 5.2-fold (0.71 log units) above the measured one; the whole stated range lies above it.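

Until this result, every compound shown carried methylsulfanyl on the aromatic carbon next to the ring nitrogen, so nothing showed whether this place matters in this assay. Going by these compounds alone, changing that one group to dimethylamino while keeping thiophen-3-yl gives an at least 5.7-fold lower number from compound 2 to compound 4 (0.75 log units; beyond the scatter), the first step in this set that can be read as lying beyond the scatter, and it shows that this place on the core can shift the read-out. The figure is only a floor, and the full size of the step stays unknown, because compound 2 sits at a limit rather than at a measured number: the limit of > 20000 nM in this assay, at which 2 of the 4 values shown sit.

Compound 4 is the only compound shown with dimethylamino, so it remains open whether the same change would have a similar effect alongside the furan-3-yl group of compound 1 or the phenyl group of compound 3. The compounds shown also leave open how this place would respond to other groups, such as a primary amine, a methoxy group or a longer chain such as ethylsulfanyl.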